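Ethenyl Linker Restored on a Chloroanilino Purine Benzamide

A few compounds are considered here, and "the series" means these few. Any claim that something is new, unique, unknown or untested is made for them only; others in the source may bear on it.

Measured compounds:
compound 1, `CCCCn1cnc2c(Nc3cccc(Cl)c3)nc(NCOCc3ccc(/C=C/C(=O)Nc4ccccc4N)cc3)nc21`: 51.1%
compound 2, `CC(C)n1cnc2c(Nc3ccccc3)nc(NCOCc3ccc(/C=C/C(=O)Nc4ccccc4N)cc3)nc21`: 53.1%
compound 3, `CC(C)n1cnc2c(Nc3cccc(Cl)c3)nc(NCOCc3ccc(C(=O)Nc4ccccc4N)cc3)nc21`: 43.2%

All three were tested in a functional assay on NCI-H460 cells (Homo sapiens) for antiproliferative activity, read by CCK-8 assay, with a stated time of 72 h, tested at 8 uM; on this read-out higher numbers stand for a stronger effect at the one concentration tested and lower numbers for a weaker effect. Compound 3 gives the smallest of the three numbers, yet its gaps to compound 1 and to compound 2 both lie within the scatter, so the three cannot be told apart on these data. Among the compounds with values here, no single-change pair exists among them.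

Compound 4, `CC(C)n1cnc2c(Nc3cccc(Cl)c3)nc(NCOCc3ccc(/C=C/C(=O)Nc4ccccc4N)cc3)nc21`, differs from compound 3 in one place: 2-((2-aminophenyl)carbamoyl)ethenyl in place of (2-aminophenyl)carbamoyl on an aromatic carbon. Compound 1 and compound 2 already carry this ethenyl-linked amide on otherwise different purines, and their values sit close to that of compound 3, so the step from compound 3 to compound 4 is expected to be small and within the scatter, estimated as a number 6.8 percentage points higher from compound 3 to compound 4 (within the scatter). Compound 4 is therefore expected to give about 50% in this assay, in a range from 38% to 62%.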

Compound 4, a percentage reported as inhibition, at one concentration (the size of the read-out at that concentration, not a potency): 61.1%
For compound 4 the middle estimate is 11.1 percentage points below the measured one; the measured number falls inside the stated range.
By their numbers in this assay, from the lowest: compounds 3, 1, 2 and 4 (each within the scatter of the next, the first and the last beyond it).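

In this assay, within the data shown here, 2-((2-aminophenyl)carbamoyl)ethenyl in place of (2-aminophenyl)carbamoyl on an aromatic carbon, para to a large group, gives a number 17.9 percentage points higher from compound 3 to compound 4 (beyond the scatter), the first single-change reading at this position. The two other single changes are not resolved: chloro in place of hydrogen on an aromatic carbon gives a number 8 percentage points higher from compound 2 to compound 4 (within the scatter), and isopropyl in place of butyl on an aromatic nitrogen gives a number 10 percentage points higher from compound 1 to compound 4 (within the scatter). Nothing presented here bears on what lies behind the step at the ethenyl position.

From the compounds shown here alone, whether the step also appears on the cores of compound 1 and compound 2 remains open, since neither has a partner lacking the ethenyl group. Also open, going by these compounds, is how a longer chain at this position, or a hydroxamic acid in place of the (2-aminophenyl)carbamoyl group, would read in this assay.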